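Swapping fluoro for chloro on a stilbene-type antiproliferative scaffold

This account rests on a few compounds, and the source may have more. Where it says the series, first, only, none or still open, it means among the compounds named here.

Measured compounds:
compound 1, `CNc1ccc(/C=C/c2c(F)cccc2Cl)cc1`, gives 7.6 nM in a functional assay on LS174T cells (Homo sapiens) for antiproliferative activity; on this read-out higher numbers stand for weaker inhibition and lower numbers for stronger inhibition;
compound 2, `CNc1ccc(/C=C/c2c(Cl)cccc2Cl)cc1`, gives 50.1 nM in this assay;
compound 3, `CN(C)c1ncc(/C=C/c2c(F)cccc2F)cn1`, gives > 200 nM in this assay, which is a limit of the assay and not a number.

Compound 1 and compound 2 differ by chloro in place of fluoro on an aromatic carbon, and this change produced a 6.6-fold higher number from compound 1 to compound 2 (0.82 log units; beyond the scatter). Compound 4, `CN(C)c1ncc(/C=C/c2c(F)cccc2Cl)cn1`, has not yet been measured in this assay. It differs from compound 3 by chloro in place of fluoro on an aromatic carbon; this is the same kind of change as that from compound 1 to compound 2, though here the place is meta to a fluoro group rather than meta to a chloro group. The difference between the core of compound 1 and the core of compound 3 is not broken down here.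

Given that compound 3 already sits at the limit of > 200 nM in this assay, at which 1 of the 3 values shown sits, and that the measured exchange raised the number by a 6.6-fold higher number from compound 1 to compound 2 (0.82 log units; beyond the scatter), compound 4 is expected to stay at or beyond that limit, with an estimated step that the limit leaves unreadable from compound 3 to compound 4. Compound 4 is therefore estimated at 1000 nM, spanning 200 nM to 6000 nM.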

Compound 4, half-maximal inhibitory concentration: > 200 nM
Compound 4 gave a limit, no number (the forecaster's own chance of this, stated with the estimate: 80%); the middle value lies beyond the limit too.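

In this assay compound 4 gives > 200 nM, which is a limit of the assay and not a number. Compound 3 and compound 4 share one limit, and no step between them can be read: the limit of > 200 nM in this assay, at which 2 of the 4 values shown sit.

The compounds shown leave open whether chloro in place of fluoro changes the activity of compound 3 at all.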